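Fluoro for Trifluoromethyl on Two Related Cores

This account rests on a few compounds, and the source may have more. Where it says the series, first, only, none or still open, it means among the compounds named here.

Measured compounds:
Compound 1, `CC1=CCCC(C)(C)C1/C=C/C(=O)/C=C/c1ccccc1C(F)(F)F`, gives 22600 nM in a functional assay on LNCaP cells (Homo sapiens) for cytotoxicity, read by MTT assay, with a stated time of 72 h; on this read-out lower numbers stand for stronger inhibition and higher numbers for weaker inhibition.
Compound 2, `CC1=CCCC(C)(C)C1/C=C/C(=O)/C=C/c1ccccc1F`, gives 1600 nM in this assay.
Compound 3, `CC1=C(/C=C/C(=O)/C=C/c2ccccc2C(F)(F)F)C(C)(C)CCC1O`, gives 2900 nM in this assay.

The account concerns one change made on two cores. From compound 1 to compound 2 the change is fluoro in place of trifluoromethyl on an aromatic carbon, and it produced a 14-fold lower number from compound 1 to compound 2 (1.15 log units; beyond the scatter). Compound 3 carries the trifluoromethyl on a different core; how the core of compound 3 differs from the core of compound 1 is not broken down here. Compound 3 stands close to compound 2 and well apart from compound 1 in this assay.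

Compound 4, `CC1=C(/C=C/C(=O)/C=C/c2ccccc2F)C(C)(C)CCC1O`, has not been measured. It differs from compound 3 by fluoro in place of trifluoromethyl on an aromatic carbon, the same change as from compound 1 to compound 2, made at the same kind of place: on an aromatic carbon of a six-membered aromatic ring of carbon only, ortho to a large group.

The expectation for compound 4 rests on a single measured step, and the core is not the same, so the size carries uncertainty. Compound 4 is expected to show an 8.3-fold lower number from compound 3 to compound 4 (0.92 log units; beyond the scatter), in the same direction as the measured step because that step, a 14-fold lower number from compound 1 to compound 2 (1.15 log units; beyond the scatter), was large and lay beyond the scatter. Compound 4 is therefore estimated at 350 nM, with a range from 120 nM to 1000 nM.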

Compound 4, half-maximal inhibitory concentration: 2900 nM
The estimate for compound 4 lay 8.3-fold (0.92 log units) below the measured number, and the stated range ends below it.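

In this assay, fluoro in place of trifluoromethyl on an aromatic carbon gave no change at the digits printed from compound 3 to compound 4 (within the scatter), whereas the same change on the core of compound 1 gave a 14-fold lower number from compound 1 to compound 2 (1.15 log units; beyond the scatter). In this series, therefore, the size of the step measured on one core did not carry over to the other, and the result of this change depended on the core that carried it: the same change on two cores in this assay, a 14-fold lower number (1.15 log units; beyond the scatter) from compound 1 to compound 2 and no change at the digits printed (within the scatter) from compound 3 to compound 4, 14-fold (1.15 log units) apart, beyond the scatter of two such steps. For the compounds shown here, this shows only that a step measured on one of these cores is a poor guide to the other; it rests on one pair of steps in a single cell assay and does not show which part of the cores accounts for the gap, or what the change would do on any further core.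

The compounds shown leave open how a chloro, a methoxy or a nitrile in place of trifluoromethyl on that aromatic carbon would read in this assay on each of the two cores, and whether the two cores would again part ways with those groups. They also leave open whether an amine or a carboxylic acid at that carbon would give steps that agree between the two cores.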